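A few compounds are considered here, and "the series" means these few. Any claim that something is new, unique, unknown or untested is made for them only; others in the source may bear on it.

Compound 3, with structure `O=C(Nc1ccc(Oc2ccnc3[nH]ccc23)c(F)c1)c1nccc(-c2cccc(Cl)c2)n1`, sits second highest among the three numbers recorded in a functional assay on MCF7 cells (Homo sapiens) for cytotoxicity, read by MTT assay, with a stated time of 72 h; a higher number here means a weaker inhibitor, a lower number a stronger inhibitor. In this assay compound 3 gives 1580 nM. Among the compounds with values here, its nearest neighbour is compound 1, `O=C(Nc1ccc(Oc2ccnc3[nH]ccc23)cc1)c1nccc(-c2cccc(Cl)c2)n1`, which in this assay gives 10200 nM; the one step between measured compounds that differ in a single place runs a 6.5-fold lower number from compound 1 to compound 3 (0.81 log units; beyond the scatter). Far away stands compound 2, `O=C(Nc1ccc(Oc2ccnc3[nH]ccc23)cc1)c1cc(-c2ccccc2)ncn1`, which in this assay gives 20 nM.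

Compound 4 has structure `O=C(Nc1ccc(Oc2ccnc3[nH]ccc23)c(F)c1)c1nccc(-c2ccc(Cl)cc2)n1`. It differs from compound 3 in one place: 4-chlorophenyl in place of 3-chlorophenyl on an aromatic carbon. Within the data shown here, no measured step in this set touches the chlorophenyl group itself; the only recorded step, from compound 1 to compound 3, concerns a fluoro added elsewhere, so it does not bear directly on this change. With nothing to anchor a direction, compound 4 is expected to remain close to compound 3, the step of a 1.1-fold lower number from compound 3 to compound 4 (0.02 log units; within the scatter) being estimated as one that stays within the scatter. Compound 4 is therefore estimated to give 1500 nM in this assay, with a range from 400 nM to 6000 nM.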

Compound 4, half-maximal inhibitory concentration: 9660 nM
The estimate for compound 4 lay 6.4-fold (0.81 log units) below the measured number, and the stated range ends below it.
By their numbers in this assay, from the lowest: compound 2; then compound 3; then compounds 4 and 1 (each within the scatter of the next).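

In this assay the change from 3-chlorophenyl to 4-chlorophenyl gives a 6.1-fold higher number from compound 3 to compound 4 (0.79 log units; beyond the scatter) and so shows that the number responds to where the chlorine stands on the phenyl group, although the two groups have the same atoms. Within the data shown here, the earlier single-place step concerned only the fluoro, so this is the first measured step at the chlorophenyl group, and here the 3-chlorophenyl group of compound 3 carries the lower number. Nothing measured here accounts for the difference between these two isomers.

As far as these compounds go, whether the same shift would appear on the core of compound 1, which lacks the fluoro, remains open. So does whether a methoxy group or an amine in place of the chlorine would give a number closer to that of compound 3 or that of compound 4.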